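A few compounds are considered here, and "the series" means these few. Any claim that something is new, unique, unknown or untested is made for them only; others in the source may bear on it.

Measured compounds:
- compound 1 `CNC(=O)c1cc(Oc2ccc(NC(=O)c3cc4cccnc4n(-c4ccc(OC)cc4)c3=O)cc2)ccn1`: 920 nM in a functional assay on HT-29 cells (Homo sapiens) for antiproliferative activity, read by MTT assay, with a stated time of 72 h; a lower number here means a stronger inhibitor, a higher number a weaker inhibitor
- compound 2 `CCCNC(=O)c1cc(Oc2ccc(NC(=O)c3cc4cccnc4n(-c4ccccc4F)c3=O)cc2)ccn1`: 200 nM
- compound 3 `CCCNC(=O)c1cc(Oc2ccc(NC(=O)c3cc4cccnc4n(-c4ccc(F)cc4)c3=O)cc2)ccn1`: 84 nM

Compound 3 gives the lowest number of the three in this assay; the nearest is compound 2, and the change from compound 2 to compound 3 was a 2.4-fold lower number from compound 2 to compound 3 (0.38 log units; beyond the scatter), while compound 1 stands higher still, the furthest of the three. Compound 4 `CCCNC(=O)c1cc(Oc2ccc(NC(=O)c3cc4cccnc4n(-c4ccc(OC)cc4)c3=O)cc2)ccn1` is the next step from compound 3: methoxy in place of fluoro on an aromatic carbon. Going by the values given here, no measured pair shows this exchange directly. The only step shown, a 2.4-fold lower number from compound 2 to compound 3 (0.38 log units; beyond the scatter), concerns where the fluorine sits and says nothing about a methoxy. Compound 1 carries the same methoxyphenyl as compound 4 but a shorter amide chain, and its value in this assay is far higher than that of compound 3, though the two differ in two places, so the methoxy cannot be credited with the gap. Compound 4 is therefore expected to land between these two, with a step of a 3.0-fold higher number from compound 3 to compound 4 (0.47 log units; beyond the scatter) toward a higher number. The estimate for compound 4 is 250 nM, within 80 nM to 800 nM.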

Compound 4, half-maximal inhibitory concentration: 1560 nM
Compound 4: middle estimate off by 6.2-fold (0.80 log units), on the low side; the measured number lies above the stated range.
By their numbers in this assay, from the lowest: compound 3; then compound 2; then compounds 1 and 4 (each within the scatter of the next).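

In this assay, the exchange of 4-fluorophenyl for 4-methoxyphenyl is the largest single-place step seen so far, a 19-fold higher number from compound 3 to compound 4 (1.27 log units; beyond the scatter), and the step with 2-fluorophenyl as the starting group, a 7.8-fold higher number from compound 2 to compound 4 (0.89 log units; beyond the scatter), also exceeds the one that moves the fluorine. With the 4-methoxyphenyl in place, ethyl in place of hydrogen on the amide chain gives a 1.7-fold higher number from compound 1 to compound 4 (0.23 log units; within the scatter), so the length of this chain makes no readable difference alongside that aryl group. Nothing available explains why the methoxy exchange gives so large a step.

Going by these compounds, whether a chloro, a methyl or a hydroxy at this position would stay close to fluoro or fall with methoxy remains open. So does whether the amide chain matters alongside a 4-fluorophenyl.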